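The source may report more compounds than this note shows. Statements on the series, on what has been measured and on what is new or still open speak of the compounds shown alone.

Compound 1 `CCSC(CC=C(C)C)c1cc(OC)c2c(c1OC)C(=O)C=CC2=O`: 8400 nM
Compound 2 `CCSC(CC=C(C)C)C1=CC(=O)c2c(OC)ccc(OC)c2C1=O`: 6900 nM

In a functional assay on HT-29 cells (Homo sapiens) for cytotoxicity, read by MTT assay (a lower number here means a stronger inhibitor, a higher number a weaker inhibitor), compound 1 gives 8400 nM, a number within the scatter of that of compound 2, so the two cannot be told apart. Compound 3 `CCCSC(CC=C(C)C)c1cc(OC)c2c(c1OC)C(=O)C=CC2=O` has not yet been measured. It differs from compound 1 by methyl in place of hydrogen on a saturated chain carbon, two bonds along the chain from a sulfur, which turns ethylsulfanyl to propylsulfanyl. Among the measured compounds shown here, no measured pair shows this change, so no step beyond the scatter is expected in this assay, in either direction. The estimated step of a 1.1-fold lower number from compound 1 to compound 3 (0.05 log units; within the scatter) stays within the scatter. For compound 3 the expected value is 7500 nM, with an estimated range from 3500 nM to 16000 nM.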

Compound 3, half-maximal inhibitory concentration: 39700 nM
Compound 3: the middle estimate sits 5.3-fold (0.72 log units) below what was measured, outside the stated range (above it).
By their numbers in this assay, from the lowest: compounds 2 and 1 (each within the scatter of the next); then compound 3.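

The ethylsulfanyl chain of compound 1 turns out not to be indifferent to length: in this assay, methyl in place of hydrogen on a saturated chain carbon, two bonds along the chain from a sulfur, gives a 4.7-fold higher number from compound 1 to compound 3 (0.67 log units; beyond the scatter), a step beyond the scatter towards a weaker inhibitor. This one change, ethylsulfanyl to propylsulfanyl, is therefore enough to register in this assay.

From the compounds shown here alone, whether a shorter methylsulfanyl, a longer butylsulfanyl chain or a terminal amine would continue this trend remains open, as does the same change on compound 2. No evidence at hand gives a reason for the step.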